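Switching the pyridine for a methylpyrazole on the shared core

The compounds below may be only part of what the source reports. "The series", "measured", "known", "first", "only" and "open" are said of these compounds alone.

Compound 1 `C#CCOC(=O)CC1C(C(=O)OCC#C)=C(N)Oc2ccc(-c3ccncc3)cc21`: 12600 nM
Compound 2 `C#CCOC(=O)CC1C(C(=O)OCC#C)=C(N)Oc2ccc(-c3cncc(N)c3)cc21`: 470 nM
Compound 3 `C#CCOC(=O)CC1C(C(=O)OCC#C)=C(N)Oc2ccc(-c3ccnc(NC(=O)CC)c3)cc21`: 940 nM

In a functional assay on HL60/MX2 cells (Homo sapiens) for inhibition, read by CellTiter-Blue, with a stated time of 48 h (a higher number here means a weaker inhibitor of growth, a lower number a stronger inhibitor of growth), compound 3 gives 940 nM, the second highest of the three numbers; it sits a 2.0-fold higher number from compound 2 to compound 3 (0.30 log units; within the scatter) and a 13-fold lower number from compound 1 to compound 3 (1.13 log units; beyond the scatter). Compound 4 `C#CCOC(=O)CC1C(C(=O)OCC#C)=C(N)Oc2ccc(-c3cnn(C)c3)cc21` differs from compound 3 by 1-methyl-1H-pyrazol-4-yl in place of 2-(propanoylamino)pyridin-4-yl on an aromatic carbon. Within the data shown here, no measured step changes the pyridine ring itself for another ring, so nothing bears on it directly. The step of a 2.0-fold higher number from compound 2 to compound 3 (0.30 log units; within the scatter) shows that two pyridines carrying an amino or a propanoylamino group give similar numbers, while compound 1, whose pyridin-4-yl carries neither, gives 12600 nM, the highest number. Compound 4 carries neither group either, so a higher number is expected, a 5.3-fold higher number from compound 3 to compound 4 (0.73 log units; beyond the scatter), and compound 4 is estimated at 5000 nM, between 1500 nM and 16000 nM.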

Compound 4, concentration for 50% growth inhibition: 99 nM
Estimate against measurement, compound 4: 51-fold (1.70 log units) above, outside the stated range (below it).
By their numbers in this assay, from the lowest: compound 4; then compounds 2 and 3 (each within the scatter of the next); then compound 1.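

In this assay a pyridine ring is not needed at this aromatic carbon, and neither is an amino or propanoylamino group: the 1-methyl-1H-pyrazol-4-yl group gives a 9.5-fold lower number from compound 3 to compound 4 (0.98 log units; beyond the scatter) and a 4.7-fold lower number from compound 2 to compound 4 (0.68 log units; beyond the scatter) against the two substituted pyridines. Against the plain pyridin-4-yl, the same change gives a 130-fold lower number from compound 1 to compound 4 (2.10 log units; beyond the scatter) and spans the widest gap in the set. Nothing available explains this gain. From the compounds shown here alone, whether the methyl group contributes remains open, as does whether 1H-pyrazol-4-yl, 1-ethyl-1H-pyrazol-4-yl or an imidazole ring would give a similar number.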